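The source may hold more compounds than are shown below. What is called first, only, known or untested is meant among the compounds shown, and "the series" means these compounds.

Measured so far in an ADME assay on BJ cells (Homo sapiens) for antiproliferative activity, with a stated time of 72 h; a lower number here means that less compound is needed, a higher number that more compound is needed for the effect:
- compound 1 `COc1ccc(-c2cc(=O)c3c(OC)cc(OC)cc3n2S(=O)(=O)c2ccc([N+](=O)[O-])cc2)cc1`: > 29300 nM
- compound 2 `COc1ccc(-c2cc(=O)c3c(OC)cc(OC)cc3n2S(=O)(=O)c2ccc(Br)cc2)cc1`: > 86200 nM
- compound 3 `COc1ccc(-c2cc(=O)c3c(OC)cc(OC)cc3n2S(=O)(=O)c2ccc(OC)cc2)cc1`: > 82700 nM

Compound 1 gives only a limit of the assay in this assay, > 29300 nM, not a number. Compound 2 likewise gives a limit, > 86200 nM. Compound 3 also gives a limit, > 82700 nM. Compound 3 therefore stands at a limit, and the two other values of the series are limits as well (the limit of > 29300 nM in this assay, at which 1 of the 3 values shown sits, (the limit of > 82700 nM in this assay, at which 1 of the 3 values shown sits), (the limit of > 86200 nM in this assay, at which 1 of the 3 values shown sits)). All three steps among the measured compounds are unreadable: a step that the two limits leave unreadable from compound 1 to compound 2, a step that the two limits leave unreadable from compound 1 to compound 3, a step that the two limits leave unreadable from compound 2 to compound 3.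

The next compound, compound 4 `COc1ccc(-c2cc(=O)c3c(OC)cc(OC)cc3n2S(=O)(=O)c2ccc(Br)s2)cc1`, differs from compound 3 by 5-bromothiophen-2-yl in place of 4-methoxyphenyl on a sulfonyl sulfur. No measured step touches the ring on the sulfonyl sulfur itself; the three steps shown only exchange a group on that ring and are unreadable. With every value of the series at a limit, compound 4 is expected to give a limit too, so the step of an at least 1.0-fold lower number from compound 3 to compound 4 (0.01 log units; that floor lies within the scatter) is expected to be none that can be read. The estimate for compound 4 in this assay is 80000 nM, with a range of 30000 nM to 200000 nM.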

Compound 4, half-maximal effective concentration: > 48200 nM
Compound 4 was reported as a limit; the forecaster's own chance of this, stated with the estimate: 85%; the middle value does not contradict the limit.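

In this assay compound 4 gives only a limit, > 48200 nM, so its steps from compound 1, compound 2 and compound 3 cannot be read. The compounds shown leave open whether any group on the sulfonyl sulfur gives a number rather than a limit, and how 5-bromothiophen-2-yl compares with the phenyl groups.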